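A few compounds are considered here, and "the series" means these few. Any claim that something is new, unique, unknown or untested is made for them only; others in the source may bear on it.

Three compounds have values in an ADME assay (Rattus norvegicus, strain Han-wistar) for pharmacokinetics, at a dose of 1.5 umol/kg by the intravenous route (a lower number here means slower removal, a higher number faster removal of the compound), as follows.

- compound 1 `CNC(=O)CN1CCC(c2cc3c(-c4ccc(=O)n(C(C)C)c4)ccnc3[nH]2)CC1` gives 89 mL/min/kg
- compound 2 `CC(C)n1nc(-c2ccnc3[nH]c(C4CCN(CC(=O)N(C)C)CC4)cc23)ccc1=O` gives 72 mL/min/kg
- compound 3 `CC(C)n1cc(-c2ccnc3[nH]c(C4CCN(CC(=O)N(C)C)CC4)cc23)cnc1=O` gives 72 mL/min/kg

Compound 1 stands within the scatter of both compound 2 and compound 3. Compound 4 `CC(C)n1cc(-c2ccnc3[nH]c(C4CCN(CC(=O)N(C)C)CC4)cc23)ccc1=O` differs from compound 1 by one change, (methyl in place of hydrogen on an amide-type nitrogen), methyl in place of hydrogen on an amide-type nitrogen, which turns methylcarbamoyl to dimethylcarbamoyl. For the measured compounds named here, no measured step isolates this change. Going by the values given here, the only measured step, no change at the digits printed from compound 2 to compound 3 (within the scatter), leaves the dimethylcarbamoyl group in place and stays within the scatter. Compound 2 and compound 3 both carry that group, and their values sit level with that of compound 1. No change beyond the scatter is therefore expected in this assay. The expected step is a 1.2-fold lower number from compound 1 to compound 4 (0.07 log units; within the scatter). Compound 4 is estimated at 76 mL/min/kg, with an expected range from 48 mL/min/kg to 115 mL/min/kg.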

Compound 4, clearance: 77 mL/min/kg
For compound 4 the middle estimate is 1.0-fold (0.01 log units) below the measured one, within the range that was stated.
By their numbers in this assay, from the lowest: compounds 2, 3, 4 and 1 (each within the scatter of the next).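

In this assay, methyl in place of hydrogen on the amide-type nitrogen now has a measured step of its own (a 1.2-fold lower number from compound 1 to compound 4 (0.06 log units; within the scatter)), so turning methylcarbamoyl to dimethylcarbamoyl leaves clearance within the scatter. With the dimethylcarbamoyl group held, exchanging the aromatic group on the core also stays within the scatter (a 1.1-fold higher number from compound 3 to compound 4 (0.03 log units; within the scatter); a 1.1-fold higher number from compound 2 to compound 4 (0.03 log units; within the scatter)). As far as these compounds go, whether a carboxylic acid or a longer chain in place of (dimethylcarbamoyl)methyl would move clearance beyond the scatter remains open. No available evidence explains why clearance stays so close across these compounds.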